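The source may hold more compounds than are shown below. What is called first, only, known or untested is meant among the compounds shown, and "the series" means these compounds.

Of the compounds shown here, three sharing one core have been measured in a functional assay on the whole organism (strain Wistar) for inhibition, with Rattus norvegicus as the target, read by paw edema, with stated times of 60 min and 4 h, at a dose of 100 mg/kg by the oral route; a higher number here means more inhibition at the dose given (going by the name of the read-out), a lower number less inhibition. Compound 1, `COc1cc2c(cc1OC)C(CC(N)=O)CC2`, gives 31.3%. Compound 2, `CCCCCCNC(=O)CC1CCc2cc(OC)c(OC)cc21`, gives 42.1%. Compound 3, `COc1cc2c(cc1OC)C(CC(=O)N1CCCC1)CC2`, gives 24.2%, the lowest of the three numbers, although its gap to compound 1 is within the scatter and only its gap to compound 2 is beyond it.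

Compound 4, `COc1cc2c(cc1OC)C(CC(=O)N1CCNCC1)CC2`, is unmeasured; it differs from compound 3 only at the carbonyl carbon: piperazin-1-yl in place of pyrrolidin-1-yl on a carbonyl carbon. Going by the values given here, two measured steps touch the same place. The step of a number 7.1 percentage points lower from compound 1 to compound 3 (within the scatter) shows that exchanging the open amino group for a ring stays within the scatter, while the step of a number 17.9 percentage points lower from compound 2 to compound 3 (beyond the scatter) shows a modest drop when the hexylamino group is replaced by the ring. Among the compounds with values here, the new group keeps a ring but adds one hydrogen-bond donor and one acceptor, a change for which no measured step exists, so compound 4 is expected to sit close to compound 3, with the step of a number 3.8 percentage points higher from compound 3 to compound 4 (within the scatter) estimated to lie within the scatter. Compound 4 is therefore estimated at 28%, with a range from 12% to 44%.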

Compound 4, a percentage reported as inhibition, in the whole organism at one dose (the size of the read-out at that dose, not a potency): 40.6%
For compound 4 the middle estimate is 12.6 percentage points below the measured one, within the range that was stated.
By their numbers in this assay, from the lowest: compounds 3, 1, 4 and 2 (each within the scatter of the next, the first and the last beyond it).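

In this assay, the kind of ring on the carbonyl carbon matters: piperazin-1-yl in place of pyrrolidin-1-yl gives a step beyond the scatter (a number 16.4 percentage points higher from compound 3 to compound 4 (beyond the scatter)). A ring at this place therefore does not in itself go with a low number, as compound 4 cannot be told apart from the hexylamino compound (a number 1.5 percentage points lower from compound 2 to compound 4 (within the scatter)) or from the compound with the plain amino group (a number 9.3 percentage points higher from compound 1 to compound 4 (within the scatter)). No measurement shown here explains the difference between the two rings.

The compounds shown leave open whether the second ring nitrogen or the larger ring goes with the higher number, a question that piperidin-1-yl and morpholin-4-yl at the same place could help to separate. On these data alone, how chains shorter or longer than hexyl on the amide nitrogen compare also remains open.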